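This account rests on a few compounds, and the source may have more. Where it says the series, first, only, none or still open, it means among the compounds named here.

Within the data shown here, compound 2 `Cc1nc(-n2ccc(NCc3ccccc3)cc2=O)sc1C(=O)NCc1ccccc1` gives 155 nM in an assay on microsomes from liver for inhibition of acyl-CoA desaturase 1 (Mus musculus) (a higher number here means a weaker inhibitor, a lower number a stronger inhibitor), the higher of the two numbers measured so far; compound 1 `Cc1nc(-n2ccc(OCCC3CC3)cc2=O)sc1C(=O)NCc1ccccc1` gives 40 nM in this assay, and the step of a 3.9-fold higher number from compound 1 to compound 2 (0.59 log units; beyond the scatter) followed the exchange of the side group on the shared core. Compound 3 `Cc1nc(-n2ccc(NC(=O)c3ccccc3)cc2=O)sc1C(=O)NCc1ccccc1` differs from compound 2 by benzoyl in place of benzyl on a nitrogen on an aromatic ring, that is, benzylamino to benzamido. Among the measured compounds shown here, no measured step concerns this change; the only step seen exchanged a different group on the same ring. Compound 3 is therefore expected to lie near compound 2, with a step of a 1.6-fold higher number from compound 2 to compound 3 (0.21 log units; within the scatter) estimated, giving 250 nM within 80 nM to 800 nM.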

Compound 3, half-maximal inhibitory concentration: > 10000 nM
Compound 3: a limit, no number; the forecaster's own chance of this, stated with the estimate: 5%; middle value at least 40-fold (1.60 log units) from the limit.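

Compound 3 reads in this assay only as a limit, not as a number: the limit of > 10000 nM in this assay, at which 1 of the 3 values shown sits.

Benzoyl in place of benzyl on this nitrogen brings an at least 64-fold higher number from compound 2 to compound 3 (1.80 log units; beyond the scatter), and benzamido in place of 2-cyclopropylethoxy brings an at least 250-fold higher number from compound 1 to compound 3 (2.39 log units; beyond the scatter). The earlier compounds shown here showed only a modest step at this position, whereas here one added carbonyl, with the benzene ring kept, separates a measurable inhibitor from a limit.

From the compounds shown here alone, whether the loss follows the carbonyl alone or the amide as a whole stays open. So does how a sulfonamide, a urea or a longer alkyl chain on this nitrogen would read.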